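The compounds below may be only part of what the source reports. "The series", "measured", "known", "first", "only" and "open" are said of these compounds alone.

Compound 1, with the structure `O=C(O)c1cccc([C@H]2C[C@@H](c3ccc(OCc4c(-c5c(Cl)cccc5Cl)noc4C4CC4)cc3Cl)C2)c1`, and compound 2, with the structure `O=C(O)c1cccc(C2CC2c2ccc(OCc3c(-c4c(Cl)cccc4Cl)noc3C3CC3)cc2Cl)c1`, share a common core and differ only in the ring that joins the carboxyphenyl group to the rest of the molecule. In an assay on isolated protein for agonist activity at Bile acid receptor (Homo sapiens), read by FRET (on this read-out lower numbers stand for smaller maximal responses and higher numbers for larger maximal responses), compound 1 gives 99%. In this assay compound 2 gives 102%, and the two numbers lie within the usual scatter of each other, so compound 2 stands alongside compound 1 rather than apart from it. Compound 3, with the structure `O=C(O)c1ccc(C2CC2c2ccc(OCc3c(-c4c(Cl)cccc4Cl)noc3C3CC3)cc2Cl)cn1`, has not yet been measured. The change from compound 2 to compound 3 is 6-carboxypyridin-3-yl in place of 3-carboxyphenyl on a saturated ring carbon. Both measured compounds reach a maximal response close to the reference, and nothing among them tests a change of this kind, so the step is expected to be none beyond the scatter. On that basis compound 3 is expected to give 98% in this assay, with a range from 82% to 112%, which means an expected step of a number 4 percentage points lower from compound 2 to compound 3 (within the scatter).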

Compound 3, largest response reached (reported as efficacy), in percent of the reference or control that the assay uses: 101%
The estimate for compound 3 lay 3 percentage points below the measured number; low and high end bracket the measured number.
By their numbers in this assay, from the lowest: compounds 1, 3 and 2 (each within the scatter of the next).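

In this assay, among these compounds, placing 6-carboxypyridin-3-yl in place of 3-carboxyphenyl on a saturated ring carbon of the three-membered ring amounts to a number 1 percentage points lower from compound 2 to compound 3 (within the scatter), the first evidence here on a change to the aromatic ring that carries the acid. Compounds 1 and 2 differ only in the ring that joins the carboxyphenyl group to the rest of the molecule, so they could not show that a ring nitrogen is tolerated at this position; compound 3 shows that, for this read-out, it leaves the largest response within the scatter of that of compound 2. Nothing available explains this outcome.

The compounds shown leave open whether the same holds for a pyrimidine ring, or for a pyridine with its nitrogen elsewhere, and whether the carboxylic acid itself could give way to a primary amide or a tetrazole. They also leave open how the concentration needed to reach this response compares between compound 2 and compound 3, since the largest response does not tell that.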